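This account rests on a few compounds, and the source may have more. Where it says the series, first, only, none or still open, it means among the compounds named here.

Measured so far:
- compound 1, `CC1(CN)CCN(c2c(F)cc3c(=O)c(C(=O)O)cn(C4CC4)c3c2Cl)C1`: 8 ug/mL
- compound 2, `COc1c(N2CCC(C)(CN)C2)c(F)cc2c(=O)c(C(=O)O)cn(C3CC3)c12`: 38 ug/mL
- compound 3, `CNCC1(C)CCN(c2c(F)cc3c(=O)c(C(=O)O)cn(C4CC4)c3c2Cl)C1`: 23 ug/mL

These three compounds share one core and were tested in a functional assay on V79 cells (Cricetulus griseus) for cytotoxicity, read by colony formation; on this read-out higher numbers stand for weaker inhibition and lower numbers for stronger inhibition. Two single changes link them. From compound 1 to compound 2 the change is methoxy in place of chloro on an aromatic carbon, and it gave a 4.8-fold higher number from compound 1 to compound 2 (0.68 log units; beyond the scatter). From compound 1 to compound 3 the change is methyl in place of hydrogen on an amine nitrogen, and it gave a 2.9-fold higher number from compound 1 to compound 3 (0.46 log units; beyond the scatter). Compound 2 and compound 3 are not linked by a single change; their two values in this assay lie within the usual scatter of each other, so nothing can be said about their order.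

Compound 4, `CNCC1(C)CCN(c2c(F)cc3c(=O)c(C(=O)O)cn(C4CC4)c3c2OC)C1`, has not yet been measured. It differs from compound 3 by methoxy in place of chloro on an aromatic carbon. Going by the values given here, this is the same kind of change as the one from compound 1 to compound 2, but not the same: in compound 1 the place is ortho to a 3-(aminomethyl)-3-methylpyrrolidin-1-yl group, while in compound 3 it is ortho to a 3-methyl-3-((methylamino)methyl)pyrrolidin-1-yl group. The two cores differ by methyl in place of hydrogen on an amine nitrogen.

Among the compounds with values here, for compound 4 the step in this assay is expected to be about a 4.3-fold higher number from compound 3 to compound 4 (0.64 log units; beyond the scatter), because the same kind of change gave a 4.8-fold higher number from compound 1 to compound 2 (0.68 log units; beyond the scatter) and there is no second example to show how the step depends on the neighbouring group. Compound 4 is therefore estimated at 100 ug/mL, with a likely range from 40 ug/mL to 250 ug/mL.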

Compound 4, half-maximal inhibitory concentration: 120 ug/mL
For compound 4 the middle estimate is 1.2-fold (0.08 log units) below the measured one, and the stated range covers the measured number.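

In this assay, methoxy in place of chloro on the aromatic carbon gave a 5.2-fold higher number from compound 3 to compound 4 (0.72 log units; beyond the scatter), and this step carried over closely from one core to the other: the same change on two cores in this assay, a 4.8-fold higher number (0.68 log units; beyond the scatter) from compound 1 to compound 2 and a 5.2-fold higher number (0.72 log units; beyond the scatter) from compound 3 to compound 4, 1.1-fold (0.04 log units) apart, within the scatter of two such steps. Methyl in place of hydrogen on the amine nitrogen gave a 3.2-fold higher number from compound 2 to compound 4 (0.50 log units; beyond the scatter), and it carried over just as closely: the same change on two cores in this assay, a 2.9-fold higher number (0.46 log units; beyond the scatter) from compound 1 to compound 3 and a 3.2-fold higher number (0.50 log units; beyond the scatter) from compound 2 to compound 4, 1.1-fold (0.04 log units) apart, within the scatter of two such steps. These two agreements are really one observation seen from two sides, since compounds 1 to 4 form a single square of the two changes, so they show that the changes simply add up within these four compounds but do not show that either step would hold on a core that differs in any other way.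

From the compounds shown here alone, it remains open whether an ethoxy or bromo group in place of the methoxy would follow the same pattern, or whether an ethyl group on the amine nitrogen would behave as the methyl does. Also open, going by these compounds, is whether the steps would keep their size if the cyclopropyl group or the carboxylic acid of the shared core were replaced.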